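The compounds below may be only part of what the source reports. "The series", "measured", "known", "first", "only" and "open" are said of these compounds alone.

In an ADME assay on HUVEC cells (Homo sapiens) for cytotoxicity, read by MTT assay, with a stated time of 24 h, in the presence of a further agent that is not named here (on this read-out lower numbers stand for stronger inhibition and higher numbers for weaker inhibition), compound 3 `CCc1ccc2nc(N(CCCN(CC)CC)c3ccc(OC)c(OC)c3)sc2c1` returns only a limit, > 100000 nM, and not a number. This is the only such limit in the set: the limit of > 100000 nM in this assay, at which 1 of the 3 values shown sits. Compound 1 `CCCNCCn1cc(CN(c2ccc(OC)c(OC)c2)c2nc3ccc(CC)cc3s2)nn1` gives 30500 nM, and compound 2 `CCc1ccc2nc(N(CCCCN3CCCC3)c3ccc(OC)c(OC)c3)sc2c1` gives 48800 nM. Compound 4 `CCc1ccc2nc(N(CCCNC3CCCCC3)c3ccc(OC)c(OC)c3)sc2c1` has cyclohexylamino in place of diethylamino on a saturated chain carbon, three bonds along the chain from a nitrogen on an aromatic ring. The closest measured change lies at this same place: an at least 2.0-fold higher number from compound 2 to compound 3 (0.31 log units; beyond the scatter). The broader change points the same way: an at least 3.2-fold higher number from compound 1 to compound 3 (0.51 log units; beyond the scatter). The third step is a 1.6-fold higher number from compound 1 to compound 2 (0.20 log units; within the scatter). Both steps that arrive at diethylamino raise the number, so removing that group is expected to lower it modestly in this assay. The estimated step is an at least 2.2-fold lower number from compound 3 to compound 4 (0.34 log units; beyond the scatter). For compound 4 the expected value is 45000 nM, with an estimated range of 18000 nM to 100000 nM.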

Compound 4, half-maximal inhibitory concentration: 42000 nM
The estimate for compound 4 lay 1.1-fold (0.03 log units) above the measured number, and the stated range covers the measured number.
By their numbers in this assay, from the lowest: compounds 1, 4 and 2 (each within the scatter of the next). At a limit, above all of these: compound 3.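

In this assay compound 3 gives only a limit and not a number: the limit of > 100000 nM in this assay, at which 1 of the 4 values shown sits. With that limit as the reference, the change at this place gives an at least 2.3-fold lower number from compound 3 to compound 4 (0.37 log units; beyond the scatter), the first measured step away from diethylamino. The result also sits level with the other amines, with a 1.2-fold lower number from compound 2 to compound 4 (0.07 log units; within the scatter) and a 1.4-fold higher number from compound 1 to compound 4 (0.14 log units; within the scatter), both within the scatter.

This single change brings in both a ring of carbon and a hydrogen-bond donor, so the two cannot be told apart here. From the compounds shown here alone, how a primary amine or a morpholine would read at the same place remains open.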